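The source may hold more compounds than are shown below. What is called first, only, known or untested is meant among the compounds shown, and "the series" means these compounds.

Measured so far:
Compound 1, `O=C(Nc1ccc(C(F)(F)F)cc1)c1csc(-c2c(Cl)cccc2Cl)n1`: in an assay on CHO cells, read by calcium flux (a higher number here means a weaker inhibitor, a lower number a stronger inhibitor), compound 1 reaches only the assay limit of > 4000 nM.
Compound 2, `O=C(Nc1ccc(C(F)(F)F)cc1)c1csc(Nc2ccccc2Cl)n1`: in this assay compound 2 gives 1750 nM.

Compound 2 holds the only actual number shown. The value of compound 1 is a limit (the limit of > 4000 nM in this assay, at which 1 of the 2 values shown sits). The step from compound 1 to compound 2 gave an at least 2.2-fold lower number from compound 1 to compound 2 (0.35 log units; beyond the scatter), but it alters a different group, so it bears only loosely on the step to compound 3, `Cc1cccc(C)c1Nc1nc(C(=O)Nc2ccc(C(F)(F)F)cc2)cs1`, where (2,6-dimethylphenyl in place of 2-chlorophenyl on a nitrogen on an aromatic ring). With no closer comparison in hand, compound 3 is expected to sit near compound 2, a 1.2-fold lower number from compound 2 to compound 3 (0.07 log units; within the scatter). The estimate for compound 3 is 1500 nM, between 500 nM and 5000 nM.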

Compound 3, half-maximal inhibitory concentration: 90 nM
Compound 3: middle estimate off by 17-fold (1.22 log units), on the high side; the measured number lies below the stated range.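

Replacing 2-chlorophenyl with 2,6-dimethylphenyl on the nitrogen gave a 19-fold lower number from compound 2 to compound 3 (1.29 log units; beyond the scatter) in this assay, showing that the reading at this position depends strongly on the group carried by that nitrogen. The wider change to (2,6-dimethylphenyl)amino in place of 2,6-dichlorophenyl on the aromatic carbon gave an at least 44-fold lower number from compound 1 to compound 3 (1.64 log units; beyond the scatter). That step has no fixed size because compound 1 stands at a limit: the limit of > 4000 nM in this assay, at which 1 of the 3 values shown sits.

The compounds shown leave open whether both methyl groups are needed. From the compounds shown here alone, how 2-methylphenyl or 2,6-diethylphenyl on the same nitrogen would read also remains unknown.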